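Swapping the Acetyl Group on an Aromatic Oxygen

A few compounds are considered here, and "the series" means these few. Any claim that something is new, unique, unknown or untested is made for them only; others in the source may bear on it.

Measured in a functional assay on SK-N-SH cells (Homo sapiens) for cytotoxicity, with a stated time of 5 days; a higher number here means a weaker inhibitor, a lower number a stronger inhibitor:
Compound 1 `COc1cc(OC)c(C(C#CCCc2ccc(O[Si](C)(C)C(C)(C)C)cc2)CC(=O)c2ccc(O)cc2)c(OC)c1`: 18100 nM
Compound 2 `COc1cc(OC)c(C(C#CCCc2ccc(O[Si](C)(C)C(C)(C)C)cc2)CC(=O)c2ccc(OC(C)=O)cc2)c(OC)c1`: 11700 nM

Compound 2 stands level with compound 1 on these numbers, as the two values lie within the usual scatter of each other and neither can be ranked ahead. Only these two compounds have been measured, so the comparison offers little to go on.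

The next compound is compound 3 `COc1cc(OC)c(C(C#CCCc2ccc(O[Si](C)(C)C(C)(C)C)cc2)CC(=O)c2ccc(O[Si](C)(C)C(C)(C)C)cc2)c(OC)c1`, which has not yet been measured. The change from compound 2 is a group of 7 heavy atoms (6 carbon, 1 silicon; no ring) in place of a group of 3 heavy atoms (2 carbon, 1 oxygen; no ring), on an oxygen on an aromatic ring. Among the compounds with values here, one measured step bears on it, the step at the same kind of oxygen on an aromatic ring, and it was a 1.5-fold lower number from compound 1 to compound 2 (0.19 log units; within the scatter). That step replaced hydrogen with acetyl, so it does not test the group of 7 heavy atoms at this place. Within the data shown here, with only that small step as a guide, no change beyond the scatter is expected in this assay. The expected step is a 1.0-fold higher number from compound 2 to compound 3 (0.01 log units; within the scatter). For compound 3 the estimate is 12000 nM, with an expected range from 5000 nM to 30000 nM.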

Compound 3, half-maximal inhibitory concentration: 48800 nM
The estimate for compound 3 lay 4.1-fold (0.61 log units) below the measured number; measured number above the stated range.
By their numbers in this assay, from the lowest: compounds 2 and 1 (each within the scatter of the next); then compound 3.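

In this assay, this oxygen on an aromatic ring turns out not to be indifferent to what it carries: the group of 7 heavy atoms (6 carbon, 1 silicon; no ring) in place of acetyl gives a 4.2-fold higher number from compound 2 to compound 3 (0.62 log units; beyond the scatter), and the same group in place of hydrogen gives a 2.7-fold higher number from compound 1 to compound 3 (0.43 log units; beyond the scatter). The exchange of hydrogen for acetyl had stayed within the scatter, whereas both of these steps pass beyond it, modestly and in the same direction, towards a weaker inhibitor; on these three compounds, hydrogen and acetyl are tolerated alike and only the larger group stands apart. Nothing measured here accounts for this shift.

The compounds leave open whether the rise follows the count of heavy atoms or the silicon atom, which an all-carbon group on the same oxygen, such as a longer alkyl chain, could separate. They also leave open where the change begins, and whether a methyl or a benzyl group at this place would stay level with compound 1 and compound 2 or move with compound 3.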